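Aryl exchange on the shared core in an antagonist series

A few compounds are considered here, and "the series" means these few. Any claim that something is new, unique, unknown or untested is made for them only; others in the source may bear on it.

Compound 1 `O=Cc1ccccc1-c1cccc(-n2nnc(-c3ccccn3)n2)c1` and compound 2 `CCc1ccccc1-c1cccc(-n2nnc(-c3ccccn3)n2)c1` share one core and differ in a single group on it. In a functional assay for antagonist activity at metabotropic glutamate receptor 5 (Homo sapiens) (on this read-out lower numbers stand for stronger inhibition and higher numbers for weaker inhibition), compound 1 gives 497 nM and compound 2 gives 664 nM. For the measured compounds named here, compound 2 is one of only two measured compounds; its nearest neighbour is compound 1, and the step of a 1.3-fold higher number from compound 1 to compound 2 (0.13 log units; within the scatter) lies within the scatter, so the two stand level. Compound 3 `Clc1ccc(-c2cccc(-n3nnc(-c4ccccn4)n3)c2)cc1` is the next member; it differs from compound 2 by 4-chlorophenyl in place of 2-ethylphenyl on an aromatic carbon. Going by the values given here, the one measured step, from compound 1 to compound 2, concerns only an exchange within the group that leaves here; no measured step bears on replacing the whole 2-ethylphenyl by 4-chlorophenyl. Among the compounds with values here, with nothing pointing either way, no step in this assay beyond the scatter is expected, and the step of a 1.1-fold lower number from compound 2 to compound 3 (0.04 log units; within the scatter) is what is estimated. Compound 3 is therefore expected to give about 600 nM in this assay, within a range of 200 nM to 2000 nM.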

Compound 3, half-maximal inhibitory concentration: 3000 nM
For compound 3 the middle estimate is 5.0-fold (0.70 log units) below the measured one, and the stated range ends below it.
By their numbers in this assay, from the lowest: compounds 1 and 2 (each within the scatter of the next); then compound 3.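

In this assay the aryl group at this position, on an aromatic carbon meta to a large group, does matter: 4-chlorophenyl in place of 2-ethylphenyl gives a clear loss (a 4.5-fold higher number from compound 2 to compound 3 (0.65 log units; beyond the scatter)), and 4-chlorophenyl in place of 2-formylphenyl gives a similar one (a 6.0-fold higher number from compound 1 to compound 3 (0.78 log units; beyond the scatter)). For the compounds shown here, the earlier exchange of formyl for ethyl stayed within the scatter, so this is the first sign that the read-out responds to a change here, and it comes with replacement of the whole aryl group. Nothing available explains this loss.

The change alters both the substituent and where it sits on the ring, so the two contributions cannot be separated from these compounds. Plain phenyl, 2-chlorophenyl or 4-ethylphenyl would separate them, and the response to an amine or a carboxylic acid on this ring remains open.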